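The source may report more compounds than this note shows. Statements on the series, on what has been measured and on what is new or still open speak of the compounds shown alone.

Measured so far in a functional assay on NCI-H23 cells (Homo sapiens) for cytotoxicity, read by sulforhodamine B assay, with a stated time of 72 h; on this read-out higher numbers stand for weaker inhibition of growth and lower numbers for stronger inhibition of growth:

compound 1, `O=C(Nc1ccc(C(F)(F)F)cc1)c1ccc2ccccc2n1` — > 90000 nM
compound 2, `O=C(Nc1ccc(O)cc1)c1ccc2ccccc2n1` — 102000 nM
compound 3, `CCCCCCCCC(=O)N1c2ccccc2CCC1C(=O)Nc1ccccc1C(F)(F)F` — 4220 nM

The value given for compound 1 is a limit of this assay, not a number: the limit of > 90000 nM in this assay, at which 1 of the 3 values shown sits. Compound 2 gives 102000 nM in this assay. The change from compound 1 to compound 2 is hydroxy in place of trifluoromethyl on an aromatic carbon, and the step it made, a step that the limit leaves unreadable from compound 1 to compound 2, cannot be read in size, since one end of it sits at the limit. Compound 3, on a different core, gives 4220 nM and stands lowest of the two readable numbers in this assay; the difference between its core and the core of compound 1 is not broken down here.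

Compound 4, `CCCCCCCCC(=O)N1c2ccccc2CCC1C(=O)Nc1ccccc1O`, is not yet measured in this assay. It differs from compound 3 by hydroxy in place of trifluoromethyl on an aromatic carbon. This is the same kind of change as that from compound 1 to compound 2, but not the same: in compound 2 the hydroxy sits para to a large group, in compound 4 it sits ortho to a large group. For the measured compounds named here, the one measured example of this change gives no readable step, so the expected step from compound 3 to compound 4, a 2.8-fold higher number from compound 3 to compound 4 (0.45 log units; beyond the scatter), rests only on the value of compound 3 at 4220 nM and on compound 2 at 102000 nM not lying below that of compound 1, and is set with a wide range. Compound 4 is estimated at 12000 nM in this assay, expected to fall between 2500 nM and 70000 nM.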

Compound 4, concentration for 50% growth inhibition: 55800 nM
Beside the measured number, compound 4's estimate is 4.7-fold (0.67 log units) below it; the range from low to high includes it.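

On the core of compound 3, hydroxy in place of trifluoromethyl on an aromatic carbon, ortho to a large group, makes a 13-fold higher number from compound 3 to compound 4 (1.12 log units; beyond the scatter) in this assay, and this is the only readable measure of the change in the series. On the core of compound 1, the same kind of change cannot be read in size, as compound 1 stands at a limit of the assay and not at a number: the limit of > 90000 nM in this assay, at which 1 of the 4 values shown sits.

The result therefore shows a large loss of growth inhibition on one core, but it does not show whether a step of this size carries over to the other core, and what lies behind the step is not shown either, while the two pairs also differ in where the group sits.

Left open is where another group at the same place, such as an amine or a carboxylic acid, would stand relative to compound 3 and compound 4 in this assay. Also open, going by these compounds, is how the numbers on the shared core move with a longer chain on the ring nitrogen, and whether the step from trifluoromethyl to hydroxy keeps its size there.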